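Fluoro in place of methyl: notes on compound 3

The source may report more compounds than this note shows. Statements on the series, on what has been measured and on what is new or still open speak of the compounds shown alone.

Measured in a functional assay on HT-29 cells (Homo sapiens) for cytotoxicity, read by MTT assay, with a stated time of 48 h; a higher number here means a weaker inhibitor, a lower number a stronger inhibitor:
- compound 1 `Cc1ccc(C2=NO[C@@H]3[C@H](CO)C[C@H](CO)[C@H]23)cc1`: > 50 ug/mL (a limit)
- compound 2 `N#Cc1ccc(C2=NO[C@@H]3[C@H](CO)C[C@H](CO)[C@H]23)cc1`: > 50 ug/mL (a limit)

Compound 1 stands at > 50 ug/mL, which is a limit and not a number. Compound 3 `OC[C@@H]1C[C@H](CO)[C@@H]2C(c3ccc(F)cc3)=NO[C@H]12` differs from it by one change: fluoro in place of methyl on an aromatic carbon. Among the compounds with values here, the only measured step bearing on this is a step that the two limits leave unreadable from compound 1 to compound 2, and the series so far shows (the limit of > 50 ug/mL in this assay, at which 2 of the 2 values shown sit). No step beyond the scatter is therefore expected in this assay, and another limit is the likeliest report. The expected step is a step that the limit leaves unreadable from compound 1 to compound 3. Compound 3 is estimated at 60 ug/mL, with an expected range from 25 ug/mL to 120 ug/mL.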

Compound 3, half-maximal inhibitory concentration: 17.8 ug/mL
The estimate for compound 3 lay 3.4-fold (0.53 log units) above the measured number, and the stated range ends above it.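

In this assay, the aromatic carbon para to a large group does respond to change: fluoro in place of methyl gives an at least 2.8-fold lower number from compound 1 to compound 3 (0.44 log units; beyond the scatter) and fluoro in place of cyano gives an at least 2.8-fold lower number from compound 2 to compound 3 (0.44 log units; beyond the scatter) at the same position. Compound 3 alone carries a number, so both steps have a bound but no exact size: the limit of > 50 ug/mL in this assay, at which 2 of the 3 values shown sit.

Going by these compounds, whether chloro or an amine at this position would match fluoro remains open. So does any order between compound 1 and compound 2, whose step cannot be read.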